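Chloro for Methyl on a Core That Shows No Binding

The source may report more compounds than this note shows. Statements on the series, on what has been measured and on what is new or still open speak of the compounds shown alone.

compound 2 `Cc1ccc(-c2noc3c2CCNCC3)cc1` — > 10000 nM
compound 1 `Clc1ccc(-c2n[nH]c3c2CCNCC3)cc1` — > 10000 nM

In an assay on cells for displacement of a labelled ligand from 5-hydroxytryptamine receptor 4 (Homo sapiens), read by scintillation counting, with a stated time of 1.5 h (on this read-out lower numbers stand for stronger inhibition and higher numbers for weaker inhibition), compound 2 gives > 10000 nM, a limit of measurement rather than a number. Compound 1 also gives only a limit, > 10000 nM. Within the data shown here, both values sit at the limit of > 10000 nM in this assay, at which 2 of the 2 values shown sit, so compound 2 stands level with the one other compound known. Compound 3 `Clc1ccc(-c2noc3c2CCNCC3)cc1` differs from compound 2 by chloro in place of methyl on an aromatic carbon. Among the measured compounds shown here, no measured pair differs in one place only, so no size for this change is known; in this assay no shift beyond the scatter is expected. Compound 3 is therefore estimated at 15000 nM, between 3000 nM and 60000 nM. The expected step is a step that the limit leaves unreadable from compound 2 to compound 3, most likely leaving compound 3 at the limit.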

Compound 3, inhibition constant: > 10000 nM
Compound 3 was reported as a limit; the forecaster's own chance of this, stated with the estimate: 80%; the middle value does not contradict the limit.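

Compound 3 gives > 10000 nM, a limit of the assay, so the change from compound 2 to compound 3 cannot be read. The compounds shown leave open what chloro in place of methyl does where a measured value exists.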